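The source may report more compounds than this note shows. Statements on the series, on what has been measured and on what is new or still open speak of the compounds shown alone.

Three compounds have been measured in a functional assay on PC-3 cells (Homo sapiens) for cytotoxicity, read by MTT assay, with a stated time of 72 h; on this read-out lower numbers stand for stronger inhibition of growth and higher numbers for weaker inhibition of growth:
compound 1 `N#C[Se]c1ccc(NC(=O)Oc2ccc(F)cc2)cc1` gives 11800 nM;
compound 2 `CCOC(=O)Nc1ccc([Se]C#N)cc1` gives 9900 nM;
compound 3 `N#C[Se]c1ccc(NC(=O)Oc2ccccc2)cc1` gives 9100 nM.

Compound 3 holds the lowest of the three numbers, but its gaps to compound 2 and compound 1 both lie within the scatter, so the three cannot be ranked against one another. Compound 4 `N#C[Se]c1ccc(NC(=O)Oc2ccc(Cl)cc2)cc1` differs from compound 3 by chloro in place of hydrogen on an aromatic carbon. The step that bears most on this is a 1.3-fold lower number from compound 1 to compound 3 (0.11 log units; within the scatter), where fluoro gave way to hydrogen on an aromatic carbon without moving the number beyond the scatter; a 1.1-fold lower number from compound 2 to compound 3 (0.04 log units; within the scatter) likewise left the number essentially in place. No step beyond the scatter is therefore expected in this assay; the expected step is a 1.0-fold higher number from compound 3 to compound 4 (0.02 log units; within the scatter). The estimate for compound 4 is 9500 nM, within 4500 nM to 20000 nM.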

Compound 4, concentration for 50% growth inhibition: 6400 nM
Beside the measured number, compound 4's estimate is 1.5-fold (0.17 log units) above it, and the stated range covers the measured number.
By their numbers in this assay, from the lowest: compounds 4, 3, 2 and 1 (each within the scatter of the next).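

In this assay chloro on this aromatic carbon, para to a large group, stays within the scatter of both hydrogen, with a 1.4-fold lower number from compound 3 to compound 4 (0.15 log units; within the scatter) here, and fluoro, with a 1.8-fold lower number from compound 1 to compound 4 (0.27 log units; within the scatter) here. Hydrogen, fluoro and chloro at this position therefore cannot be told apart in this assay. No measurement at hand offers an explanation for these numbers. On these data alone, whether a methoxy group, a trifluoromethyl group or an amine at this position would move the number beyond the scatter remains open. So does the effect of a longer chain in place of the ethyl group of compound 2.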